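Sulfonyl group swaps and distribution in the series

A few compounds are considered here, and "the series" means these few. Any claim that something is new, unique, unknown or untested is made for them only; others in the source may bear on it.

The compounds share one core and differ in the group on the sulfonyl sulfur. In an ADME assay on the whole organism (Rattus norvegicus, strain Sprague-Dawley) for pharmacokinetics, read by LC-MS, with a stated time of 30 min (on this read-out higher numbers stand for wider distribution into tissues and lower numbers for narrower distribution), compound 1 (`N#Cc1ccc(O[C@H]2CN(S(=O)(=O)c3ccc(Cl)cc3Cl)C[C@@]2(O)CO)cc1F`) gives 54 L/kg, compound 2 (`N#Cc1ccc(O[C@H]2CN(S(=O)(=O)c3ccc(C(F)(F)F)cc3)C[C@@]2(O)CO)cc1F`) gives 180 L/kg and compound 3 (`N#Cc1ccc(O[C@H]2CN(S(=O)(=O)c3ccc(Cl)cn3)C[C@@]2(O)CO)cc1F`) gives 12 L/kg, the lowest of the three numbers.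

The next structure is compound 4 (`N#Cc1ccc(O[C@H]2CN(S(=O)(=O)c3ccc(C(F)(F)F)nc3)C[C@@]2(O)CO)cc1F`), with this change from compound 3: 6-(trifluoromethyl)pyridin-3-yl in place of 5-chloropyridin-2-yl on a sulfonyl sulfur. In words, 6-(trifluoromethyl)pyridin-3-yl stands in place of 5-chloropyridin-2-yl.

The most relevant measurement is a 15-fold lower number from compound 2 to compound 3 (1.18 log units; beyond the scatter), a large step beyond the scatter. Compound 4 keeps the trifluoromethyl of compound 2 and has a pyridinyl group like compound 3, so it shares a feature with each end of that step. The modest steps of a 3.3-fold higher number from compound 1 to compound 2 (0.52 log units; beyond the scatter) and a 4.5-fold lower number from compound 1 to compound 3 (0.65 log units; beyond the scatter) show that a swap of this group alone can also move the number beyond the scatter. Among the measured compounds shown here, no measured compound combines trifluoromethyl with a pyridinyl group, which keeps the range wide.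

An upward move beyond the scatter is expected, covering only part of the gap to compound 2, which gives 180 L/kg. The expected step is a 3.8-fold higher number from compound 3 to compound 4 (0.57 log units; beyond the scatter). For compound 4 the estimate is 45 L/kg, with an expected range of 14 L/kg to 140 L/kg.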

Compound 4, volume of distribution at steady state: 28 L/kg
Compound 4: the middle estimate sits 1.6-fold (0.21 log units) above what was measured, within the range that was stated.
By their numbers in this assay, from the lowest: compound 3; then compounds 4 and 1 (each within the scatter of the next); then compound 2.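

In this assay, among the compounds shown here, setting 6-(trifluoromethyl)pyridin-3-yl against 4-(trifluoromethyl)phenyl on the sulfonyl sulfur gives the first comparison with trifluoromethyl on both sides (a 6.4-fold lower number from compound 2 to compound 4 (0.81 log units; beyond the scatter)), so the large drop is not tied to losing trifluoromethyl, and a pyridinyl group can carry a step beyond the scatter with that group kept. Among the pyridinyl groups, 6-(trifluoromethyl)pyridin-3-yl in place of 5-chloropyridin-2-yl also moves the number beyond the scatter (a 2.3-fold higher number from compound 3 to compound 4 (0.37 log units; beyond the scatter)), while 2,4-dichlorophenyl and 6-(trifluoromethyl)pyridin-3-yl cannot be told apart at this position (a 1.9-fold lower number from compound 1 to compound 4 (0.29 log units; within the scatter)), which shows that a pyridinyl group does not by itself separate a compound from the phenyl series here. Nothing available explains why these groups shift the distribution read-out.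

The two pyridinyl groups differ in more than chlorine against trifluoromethyl, so the share of the substituent and the share of the rest of the group in that step remain unresolved. From the compounds shown here alone, how a methoxy group or an amine on the pyridinyl ring, or a saturated group such as cyclohexyl on the sulfonyl sulfur, would read also remains open.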